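Moving the chlorine on the aryl ring of compound 2

The source may report more compounds than this note shows. Statements on the series, on what has been measured and on what is new or still open speak of the compounds shown alone.

compound 1 `O=C1CSC(c2cccc(F)c2)N1CCN1CCCCC1`: 92%
compound 2 `O=C1CSC(c2ccccc2Cl)N1CCN1CCCCC1`: 94%

In an ADME assay on Vero cells (Chlorocebus sabaeus) for cytotoxicity, read by neutral red uptake, tested at 98 ug/mL (a higher number here means a weaker effect of the compound at the concentration tested, a lower number a stronger effect), compound 1 gives 92% and compound 2 gives 94%. Of the two numbers shown, compound 2 has the higher, but the step of a number 2 percentage points higher from compound 1 to compound 2 (within the scatter) lies within the scatter, so the two cannot be told apart. Compound 3 `O=C1CSC(c2ccc(Cl)cc2)N1CCN1CCCCC1` is not yet measured; it differs from compound 2 by 4-chlorophenyl in place of 2-chlorophenyl on a saturated ring carbon. Within the data shown here, the only step that bears on this, an aryl change on the same saturated ring carbon, was a number 2 percentage points higher from compound 1 to compound 2 (within the scatter). No step beyond the scatter is expected, a number 1 percentage points lower from compound 2 to compound 3 (within the scatter). Compound 3 is estimated at 93%, within 84% to 100%.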

Compound 3, a percentage reported as activity, at one concentration (the size of the read-out at that concentration, not a potency): 74%
Beside the measured number, compound 3's estimate is 19 percentage points above it; the measured number lies below the stated range.
By their numbers in this assay, from the lowest: compound 3; then compounds 1 and 2 (each within the scatter of the next).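

In this assay the aryl group on the saturated ring carbon proves sensitive to where its halogen sits: 4-chlorophenyl in place of 2-chlorophenyl gives a number 20 percentage points lower from compound 2 to compound 3 (beyond the scatter), with the same atoms joined differently. 4-chlorophenyl in place of 3-fluorophenyl gives a number 18 percentage points lower from compound 1 to compound 3 (beyond the scatter), so compound 3 stands apart from both other compounds. No measurement at hand accounts for this shift.

Going by these compounds, whether the lower number needs chlorine itself remains open. A methoxy group or a nitrile in place of the chlorine of compound 3 would test that.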